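Adding Chloro to the Phenyl Group of Compound 3

The source may hold more compounds than are shown below. What is called first, only, known or untested is meant among the compounds shown, and "the series" means these compounds.

Measured in a physicochemical assay for solubility, in phosphate buffer, with a stated time of 18 h, at pH 7.4; a lower number here means a less soluble compound, a higher number a more soluble compound:
Compound 1 `Nc1nc(-c2ccccc2)nn1-c1ncnc2cc(Cl)ccc12`: 300 nM
Compound 2 `COc1cc2ncnc(-n3nc(-c4cccnc4)nc3N)c2cc1OC`: 27000 nM
Compound 3 `COc1cc2ncnc(-n3nc(-c4ccccc4)nc3N)c2cc1OC`: 1000 nM

Compound 3 stands second highest of the three, above compound 1 and below compound 2. Compound 4 `COc1cc2ncnc(-n3nc(-c4ccc(Cl)cc4)nc3N)c2cc1OC` has not yet been measured. It differs from compound 3 in having chloro in place of hydrogen on an aromatic carbon, phenyl to 4-chlorophenyl (chloro in place of hydrogen on an aromatic carbon). For the measured compounds named here, only one measured step bears on this, and only loosely: a 27-fold lower number from compound 2 to compound 3 (1.43 log units; beyond the scatter). Going by the values given here, that large step exchanges pyridin-3-yl for phenyl, and no measured pair shows chloro in place of hydrogen. A smaller change in the same direction is therefore expected, and the estimate is a 2.9-fold lower number from compound 3 to compound 4 (0.46 log units; beyond the scatter). For compound 4 the expected value is 350 nM, with an estimated range of 90 nM to 1200 nM.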

Compound 4, solubility: 1000 nM
Compound 4: the middle estimate sits 2.9-fold (0.46 log units) below what was measured, and the stated range covers the measured number.
By their numbers in this assay, from the lowest: compound 1; then compounds 3 and 4 (each within the scatter of the next); then compound 2.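

In this assay, for the compounds shown here, the first look at chloro in place of hydrogen on this aromatic carbon gives no change at the digits printed from compound 3 to compound 4 (within the scatter) and so shows that this change at this position leaves the number unmoved. The step of a 27-fold lower number from compound 2 to compound 4 (1.43 log units; beyond the scatter) shows that the large difference from the pyridin-3-yl compound remains with 4-chlorophenyl as it did with phenyl. Nothing available explains either result.

From the compounds shown here alone, whether an amine or a carboxylic acid at the same place would also leave the number unmoved remains open. So does whether chloro would behave the same way on the pyridin-3-yl group of compound 2.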